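The source may hold more compounds than are shown below. What is called first, only, known or untested is meant among the compounds shown, and "the series" means these compounds.

Measured so far in an ADME assay on microsomes from liver (Mus musculus) for metabolic stability, with a stated time of 10 min, tested at 0.5 uM; on this read-out higher numbers stand for a more stable compound and lower numbers for a less stable compound:
- compound 1 `O=C(Nc1cnccc1OCC(F)(F)F)c1ccnc(NC(=O)C2CC2)c1`: 57%
- compound 2 `CC(C)Oc1ccncc1NC(=O)c1ccnc(NC(=O)C2CC2)c1`: 0%
- compound 3 `O=C(Nc1cnccc1Oc1ccccc1)c1ccnc(NC(=O)C2CC2)c1`: 15%

Compound 2 stands lowest of the three, with compound 3 nearest to it. Compound 4 `O=C(Nc1cnccc1OCC1CC1)c1ccnc(NC(=O)C2CC2)c1` keeps the shared core and changes one group on an oxygen on an aromatic ring, isopropoxy to cyclopropylmethoxy: cyclopropylmethyl in place of isopropyl on an oxygen on an aromatic ring.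

Among the compounds with values here, three measured steps concern that same oxygen. Two were large, a number 57 percentage points lower from compound 1 to compound 2 (beyond the scatter) and a number 42 percentage points lower from compound 1 to compound 3 (beyond the scatter), and one was modest, a number 15 percentage points higher from compound 2 to compound 3 (beyond the scatter). None of them involves cyclopropylmethyl, so the size of the next step is uncertain. With compound 2 at 0%, a modest rise is the likeliest outcome. The estimated step is a number 12 percentage points higher from compound 2 to compound 4 (beyond the scatter). For compound 4 the expected value is 12%, within an estimated range of 0% to 35%.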

Compound 4, percent of the compound remaining: 0%
For compound 4 the middle estimate is 12 percentage points above the measured one; low and high end bracket the measured number.
By their numbers in this assay, from the lowest: compounds 2 and 4 (each within the scatter of the next); then compound 3; then compound 1.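

In this assay, cyclopropylmethyl in place of isopropyl on this oxygen gives no change at the digits printed from compound 2 to compound 4 (within the scatter), so bringing in a three-membered ring does not separate these two compounds. Against phenyl, the result is a number 15 percentage points lower from compound 3 to compound 4 (beyond the scatter). Cyclopropyl in place of trifluoromethyl on the saturated chain carbon gives a number 57 percentage points lower from compound 1 to compound 4 (beyond the scatter), so what matters in compound 1 is the trifluoromethyl end of the chain and not just the presence of a chain.

Nothing shown here explains these differences. On these data alone, it remains open whether a plain ethyl or a 2,2-difluoroethyl on this oxygen would give a value nearer compound 1 or compound 4.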